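The source may report more compounds than this note shows. Statements on the series, on what has been measured and on what is new or still open speak of the compounds shown alone.

Compound 3 `Cc1c(OCCCCOc2ccc(C(=O)O)c(F)c2)ccc(C(=O)CC(C)(C)C)c1O` gives the lowest number among the three measured compounds in an assay for positive allosteric modulation of metabotropic glutamate receptor 2 (Rattus norvegicus) (on this read-out lower numbers stand for an effect already at smaller amounts and higher numbers for an effect only at larger amounts of compound), at 80 nM. Compound 1 `Cc1c(OCCCCOc2cncc(C(=O)O)c2)ccc(C(=O)CC(C)(C)C)c1O` gives 490 nM, and compound 2 `Cc1ccc(OCCCCOc2ccc(C(=O)CC(C)(C)C)c(O)c2C)cc1C(=O)O` gives 210 nM. Compound 4 `Cc1c(OCCCCOc2ccc(C(=O)O)cc2F)ccc(C(=O)CC(C)(C)C)c1O` is not yet measured; its change from compound 3 is 4-carboxy-2-fluorophenyl in place of 4-carboxy-3-fluorophenyl on an oxygen on a saturated carbon. For the measured compounds named here, two measured steps touch this end of the molecule: a 6.1-fold lower number from compound 1 to compound 3 (0.79 log units; beyond the scatter) and a 2.6-fold lower number from compound 2 to compound 3 (0.42 log units; beyond the scatter), both described as modest. Neither of them shifts a fluorine within the same ring, so a smaller movement than those is expected here, in either direction or none beyond the scatter. For compound 4 the estimated value in this assay is 120 nM, expected to fall between 40 nM and 360 nM, which means an expected step of a 1.5-fold higher number from compound 3 to compound 4 (0.18 log units; within the scatter).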

Compound 4, half-maximal effective concentration: 75 nM
Compound 4: middle estimate off by 1.6-fold (0.20 log units), on the high side; the range from low to high includes it.
By their numbers in this assay, from the lowest: compounds 4 and 3 (each within the scatter of the next); then compound 2; then compound 1.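

In this assay, 4-carboxy-2-fluorophenyl in place of 4-carboxy-3-fluorophenyl gives a 1.1-fold lower number from compound 3 to compound 4 (0.03 log units; within the scatter) and so shows that these two fluorine placements cannot be told apart. With fluorine in its new place, the ring still outperforms the two other rings, with a 2.8-fold lower number from compound 2 to compound 4 (0.45 log units; beyond the scatter) and a 6.5-fold lower number from compound 1 to compound 4 (0.82 log units; beyond the scatter) as the steps. Nothing shown explains this result.

Still open, as far as these compounds go, is whether a chlorine or a methoxy group in place of the fluorine would give a similar number. Also open, from the compounds shown here alone, is whether a tetrazole could replace the carboxylic acid.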